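Moving the Pyridine Nitrogen on the Sulfonamide

The source may hold more compounds than are shown below. What is called first, only, known or untested is meant among the compounds shown, and "the series" means these compounds.

Compound 1 `CCc1ccccc1N(CC(=O)NCc1cccc(OC(F)(F)F)c1)S(=O)(=O)c1ccc(C)cc1` — 427 nM
Compound 2 `Cc1ccc(S(=O)(=O)N(CC(=O)NCc2ccc(Cl)cc2)c2cccnc2C)cc1` — 676 nM

Two compounds have been run in a functional assay on CHO-K1 cells for antagonist activity at prostaglandin E2 receptor EP1 subtype (Homo sapiens), read by FLIPR and calcium flux; on this read-out higher numbers stand for weaker inhibition and lower numbers for stronger inhibition. Compound 1 gives 427 nM, and compound 2 gives 676 nM. Compound 2 therefore carries the higher of the two numbers, but its nearest neighbour is compound 1 and the gap between them lies within the scatter, so the two cannot be separated on this evidence.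

Compound 3 `Cc1ccc(S(=O)(=O)N(CC(=O)NCc2ccc(Cl)cc2)c2cccc(C)n2)cc1` has not yet been measured. It keeps every atom of compound 2 and differs from it only in how the pyridine is joined: 6-methylpyridin-2-yl in place of 2-methylpyridin-3-yl on a sulfonamide nitrogen. Going by the values given here, no pair of measured compounds shows what such a rearrangement does to this assay, so there is nothing to set a direction from. The change is expected to stay within the scatter rather than to produce a clear step. On that basis the step from compound 2 to compound 3 is estimated at a 1.0-fold higher number from compound 2 to compound 3 (0.02 log units; within the scatter). Compound 3 is estimated at 700 nM, with a plausible range from 250 nM to 2000 nM.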

Compound 3, inhibition constant: < 1450 nM
Compound 3 was reported as a limit; the forecaster's own chance of this, stated with the estimate: 10%; the middle value lies beyond the limit too.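

In this assay compound 3 gives < 1450 nM, which is a limit of the assay and not a number. Going by these compounds alone, no step between compound 2 and compound 3 can be read from it. The compounds shown leave open what 6-methylpyridin-2-yl in place of 2-methylpyridin-3-yl on a sulfonamide nitrogen does in this assay.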